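The source may report more compounds than this note shows. Statements on the series, on what has been measured and on what is new or still open speak of the compounds shown alone.

Among the three compounds measured so far, compound 2 `COc1ccc(N/C(CCNC2=CC(=O)c3ccccc3C2=O)=N\S(=O)(=O)c2ccc(C)cc2)cc1OC` gives the highest number in a functional assay on MCF7 cells (Homo sapiens) for cytotoxicity, read by MTT assay, with a stated time of 48 h (on this read-out higher numbers stand for weaker inhibition and lower numbers for stronger inhibition), at 12300 nM. Compound 1 `Cc1ccc(S(=O)(=O)/N=C(/CCNC2=CC(=O)c3ccccc3C2=O)Nc2ccc(Cl)cc2)cc1` gives 7080 nM, and the step of a 1.7-fold higher number from compound 1 to compound 2 (0.24 log units; within the scatter) stays within the scatter of the method. Compound 3 `Cc1ccc(S(=O)(=O)/N=C(/CCNC2=CC(=O)c3ccccc3C2=O)NCc2ccccc2)cc1` gives 3630 nM, and here a 3.4-fold lower number from compound 2 to compound 3 (0.53 log units; beyond the scatter) reaches beyond the scatter, while a 2.0-fold lower number from compound 1 to compound 3 (0.29 log units; within the scatter) does not. All three measured steps change only the group carried on the amine nitrogen of the shared core.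

Compound 4 `COc1ccc(N/C(CCNC2=CC(=O)c3ccccc3C2=O)=N\S(=O)(=O)c2ccc(C(C)(C)C)cc2)cc1OC` differs from compound 2 elsewhere: tert-butyl in place of methyl on an aromatic carbon. For the measured compounds named here, no measured step touches this part of the molecule, so the three steps above bear on it only indirectly, by showing that the numbers move within a narrow band; the largest of them is a 3.4-fold lower number from compound 2 to compound 3 (0.53 log units; beyond the scatter), and the others stay within the scatter. For this reason the step of a 1.0-fold lower number from compound 2 to compound 4 (0.01 log units; within the scatter) is expected to lie within the scatter, with no clear direction. Compound 4 is therefore estimated to give 12000 nM in this assay, with a range from 5000 nM to 30000 nM.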

Compound 4, half-maximal inhibitory concentration: 8710 nM
Compound 4: the middle estimate sits 1.4-fold (0.14 log units) above what was measured, within the range that was stated.
By their numbers in this assay, from the lowest: compounds 3, 1, 4 and 2 (each within the scatter of the next, the first and the last beyond it).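

For the compounds shown here, compound 4 gives the first reading on a part of the molecule that the earlier steps left untouched, an aromatic carbon para to a large group, and in this assay the change from 4-methylphenyl to 4-(tert-butyl)phenyl gives a 1.4-fold lower number from compound 2 to compound 4 (0.15 log units; within the scatter). The count of heavy atoms at this place rises from 1 to 4, with no hydrogen-bond donor or acceptor on either group, and this single pair shows no readable change in the number. No evidence bearing on this result is at hand.

From the compounds shown here alone, one pair cannot say whether this position is indifferent to its substituent in general, so it remains open whether a group of another kind here, such as a carboxylic acid, an amine or a longer chain, would also stay within the scatter. Going by these compounds, it is also open whether tert-butyl would leave the number equally unmoved with the 4-chlorophenyl of compound 1 or the benzyl of compound 3 on the amine nitrogen, rather than the 3,4-dimethoxyphenyl of compound 2.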